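Methoxy to fluoro on the aromatic ring: compound 2 to compound 4

The source may report more compounds than this note shows. Statements on the series, on what has been measured and on what is new or still open speak of the compounds shown alone.

Within the data shown here, compound 2 `C#CCNC1CCc2c(SCc3cccc(OC)c3)cccc21` gives the lowest number of the three measured so far in an ADME assay on isolated protein for inhibition of Amine oxidase [flavin-containing] B (Homo sapiens) (on this read-out lower numbers stand for stronger inhibition and higher numbers for weaker inhibition), at 1520 nM. Compound 3 `C#CCNC1CCc2c(OCc3cccc(C(F)(F)F)c3)cccc21` gives 5410 nM, a gap beyond the usual scatter, and compound 1 `C#CCNC1CCc2c(SCc3ccc4ccccc4c3)cccc21` gives 69300 nM, far beyond the scatter as well. Since both gaps are beyond the scatter, compound 2 is the most potent of the measured set, with compound 1 the weakest.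

Compound 4 `C#CCNC1CCc2c(SCc3cccc(F)c3)cccc21` has not yet been measured. It differs from compound 2 in a single place: fluoro in place of methoxy on an aromatic carbon. Among the measured compounds shown here, no step between two measured compounds carries this same change, so there is no direct precedent in the set; compound 3 differs from compound 2 in more than one place, so the value of compound 3, 5410 nM, cannot be read as a guide to the methoxy-to-fluoro exchange on its own.

For the measured compounds named here, with no precedent, the expected step in this assay from compound 2 to compound 4 is small, in either direction, and most likely within the scatter: a 1.4-fold lower number from compound 2 to compound 4 (0.14 log units; within the scatter). Compound 4 is therefore estimated at 1100 nM in this assay, with a plausible range from 350 nM to 3500 nM.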

Compound 4, half-maximal inhibitory concentration: 11600 nM
Beside the measured number, compound 4's estimate is 11-fold (1.02 log units) below it, outside the stated range (above it).
By their numbers in this assay, from the lowest: compound 2; then compound 3; then compound 4; then compound 1.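

In this assay the series now has its first comparison between compounds that differ in one place: a 7.6-fold higher number from compound 2 to compound 4 (0.88 log units; beyond the scatter) and beyond the scatter, with inhibition weakened. This shows that the aromatic carbon meta to a large group is sensitive to substitution, at least for this pair, and that fluoro does not stand in for methoxy here. The exchange replaces a carbon and oxygen group bearing a hydrogen-bond acceptor with a lone fluorine bearing none, but no measurement shown separates these differences or accounts for the loss of inhibition.

Open, as far as these compounds go, is whether the trend follows group size or acceptor character, which an ethoxy, a hydroxyl, an amine or a chlorine at this same carbon would help to separate. Also open, from the compounds shown here alone, is whether the methoxy-to-fluoro step keeps its direction and size with an oxygen in the linker in place of sulfur, or on a different aromatic carbon of the benzyl ring.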